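Adding a Second Methoxy Group to Compound 2

The compounds below may be only part of what the source reports. "The series", "measured", "known", "first", "only" and "open" are said of these compounds alone.

Measured so far:
compound 1 `c1ccc2c(c1)CC2CCCN1CCN(c2cccc3c2OCCO3)CC1` gives 0.45 mg/kg in an assay for activation of Adrenergic receptor alpha-1 (Rattus norvegicus); a lower number here means that less compound is needed, a higher number that more compound is needed for the effect
compound 2 `COc1ccc2c(c1)C(CCN1CCN(c3cccc4c3OCCO4)CC1)C2` gives 1.25 mg/kg in this assay

Compound 2 holds the higher of the two numbers; compound 1 sits well below it. Compound 3 `COc1cc2c(cc1OC)C(CCN1CCN(c3cccc4c3OCCO4)CC1)C2` is not yet measured. It differs from compound 2 by methoxy in place of hydrogen on an aromatic carbon. Within the data shown here, no measured pair shows what a second methoxy does to the read-out here, so the direction of the step is open. A change no larger than the usual scatter seems the most likely outcome, so the step from compound 2 to compound 3 is estimated as a 1.2-fold higher number from compound 2 to compound 3 (0.08 log units; within the scatter). Compound 3 is therefore expected to give about 1.5 mg/kg, within a range of 0.5 mg/kg to 4.5 mg/kg.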

Compound 3, dose for half-maximal effect: 1.25 mg/kg
Beside the measured number, compound 3's estimate is 1.2-fold (0.08 log units) above it; the range from low to high includes it.
By their numbers in this assay, from the lowest: compound 1; then compounds 2 and 3 (each within the scatter of the next).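

In this assay, putting methoxy in place of hydrogen on this aromatic carbon, ortho to a methoxy group, gives no change at the digits printed from compound 2 to compound 3 (within the scatter). Among these compounds, this is the first measured step at this position, and it shows that the read-out tolerates a second methoxy group here. Nothing measured explains this outcome.

On these data alone, whether other groups at this carbon, such as a hydroxyl, an amine or a carboxylic acid, would leave the number equally undisturbed stays open. So does the effect of a longer chain, such as ethoxy, in place of this methoxy.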